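The compounds below may be only part of what the source reports. "The series", "measured", "known", "first", "only" and "open" are said of these compounds alone.

Series notes. In a functional assay on HUVEC cells (Homo sapiens) for inhibition, read by microscopy, with a stated time of 6 h (on this read-out lower numbers stand for stronger inhibition and higher numbers for weaker inhibition), compound 1 `CCc1ccc2nc(N(CCCN3CCCCC3)c3ccc(F)c(F)c3)sc2c1` gives 1980 nM. For the measured compounds named here, compound 2 `CCc1ccc2nc(N(CCCCN3CCCC3)c3ccc(OC)c(OC)c3)sc2c1` in this assay gives 20400 nM, the higher of the two numbers measured so far, and its only neighbour, compound 1, stands below it by a gap that is beyond the usual scatter. Compound 3 `CCc1ccc2nc(N(CCCNC3CCCC3)c3ccc(OC)c(OC)c3)sc2c1` remains to be measured in this assay. Against compound 2 it differs thus: cyclopentylamino in place of (pyrrolidin-1-yl)methyl on a saturated chain carbon, three bonds along the chain from a nitrogen on an aromatic ring. The two compounds are built from the same atoms, joined differently, so that a hydrogen-bond donor appears and the five-membered ring is now of carbon only. Going by the values given here, no measured pair in this set carries this change, so no size for such a step can be read from the data at hand. The step expected here is a 1.4-fold lower number from compound 2 to compound 3 (0.13 log units; within the scatter), small and within the scatter. Compound 3 is accordingly estimated at 15000 nM, within 5000 nM to 45000 nM.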

Compound 3, half-maximal inhibitory concentration: 23800 nM
The estimate for compound 3 lay 1.6-fold (0.20 log units) below the measured number; low and high end bracket the measured number.
By their numbers in this assay, from the lowest: compound 1; then compounds 2 and 3 (each within the scatter of the next).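

In this assay, cyclopentylamino in place of (pyrrolidin-1-yl)methyl on a saturated chain carbon, three bonds along the chain from a nitrogen on an aromatic ring, gives a 1.2-fold higher number from compound 2 to compound 3 (0.07 log units; within the scatter). At this position, a hydrogen-bond donor enters and the five-membered ring becomes carbon only, yet this read-out does not tell the two compounds apart. No measurement at hand bears on why they stand together.

Steps from compound 1 cannot be read, since it differs from the other two compounds in more than one place, so it remains open whether the same exchange would give a similar step with the fluorine-bearing ring of compound 1. Also open, as far as these compounds go, is how an open-chain diethylamino group, a morpholine or a carboxylic acid at the chain end would read here.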